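A few compounds are considered here, and "the series" means these few. Any claim that something is new, unique, unknown or untested is made for them only; others in the source may bear on it.

compound 1 `CO[C@H]1CC[C@H]2CCN(C)[C@H]2C1`: > 300000 nM
compound 2 `COCCO[C@H]1CC[C@H]2CCN(C)[C@H]2C1`: > 300000 nM

In an assay on HEK293 cells for antagonist activity at Neuronal acetylcholine receptor; alpha3/beta4 (Rattus norvegicus), read by FLIPR, using a membrane potential dye (a higher number here means a weaker inhibitor, a lower number a stronger inhibitor), compound 1 gives > 300000 nM, a limit of the assay and not a number. Compound 2 likewise gives only the limit > 300000 nM. Compound 2 therefore stands at the limit, and the step that the two limits leave unreadable from compound 1 to compound 2 cannot be read, since (the limit of > 300000 nM in this assay, at which 2 of the 2 values shown sit). Compound 3 `CN1CC[C@@H]2CC[C@H](O)C[C@@H]21` differs from compound 2 by hydrogen in place of 2-methoxyethyl on an oxygen on a saturated carbon. For the measured compounds named here, the single measured step bears on this change but its size is unreadable, so no direction can be drawn from it. Compound 3 is expected to stay at the limit as well, an expected step that the limit leaves unreadable from compound 2 to compound 3. For compound 3 the estimate is 500000 nM, within 100000 nM to 3000000 nM.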

Compound 3, half-maximal inhibitory concentration: > 300000 nM
Compound 3: no number, only a limit; the forecaster's own chance of this, stated with the estimate: 90%; the middle value does not contradict the limit.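

For the compounds shown here, compound 3 gives > 300000 nM, a limit of the assay and not a number, so no step among compound 1, compound 2 and compound 3 can be read. The compounds shown leave open whether the group on that oxygen affects inhibition at all.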